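Methoxycarbonyl on the phenoxymethyl ring of the coumarinyl-triazole series

This account rests on a few compounds, and the source may have more. Where it says the series, first, only, none or still open, it means among the compounds named here.

Among the measured compounds shown here, compound 2 `O=c1cc(-n2cc(COc3ccccc3)nn2)c2cc(Br)ccc2o1` stands lowest of the three numbers so far in a functional assay on MCF7 cells (Homo sapiens) for antiproliferative activity, read by MTT assay, with a stated time of 48 h; on this read-out higher numbers stand for weaker inhibition and lower numbers for stronger inhibition: compound 2 gives 1720 nM. Compound 1 `O=c1cc(-n2cc(-c3ccccc3)nn2)c2cc(Br)ccc2o1` gives 9450 nM in this assay, and compound 3 `O=c1cc(-n2cc(COc3cccnc3)nn2)c2cc(Br)ccc2o1` gives 39800 nM. The step of a 5.5-fold lower number from compound 1 to compound 2 (0.74 log units; beyond the scatter) shows that the phenoxymethyl arm is favoured over the directly bound phenyl, while a 4.2-fold higher number from compound 1 to compound 3 (0.62 log units; beyond the scatter) and a 23-fold higher number from compound 2 to compound 3 (1.36 log units; beyond the scatter) show that the ether-bound ring itself is sensitive to change, the pyridin-3-yl version being the weakest of the set.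

Compound 4 `COC(=O)c1ccccc1OCc1cn(-c2cc(=O)oc3ccc(Br)cc23)nn1` keeps the phenoxymethyl arm of compound 2 and differs from it by methoxycarbonyl in place of hydrogen on an aromatic carbon. For the measured compounds named here, no measured step adds a substituent to this ring; the only step touching it is the ring swap in a 23-fold higher number from compound 2 to compound 3 (1.36 log units; beyond the scatter), which was large. That step, rather than a direct precedent, is the guide, and it suggests that alterations here are more likely to raise the number than to lower it, though a substituent is not a ring swap and a smaller move is expected. On that basis compound 4 is expected to give 4000 nM in this assay, with a range from 1200 nM to 15000 nM, meaning an expected step of a 2.3-fold higher number from compound 2 to compound 4 (0.37 log units; beyond the scatter).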

Compound 4, half-maximal inhibitory concentration: 34100 nM
Compound 4: the middle estimate sits 8.5-fold (0.93 log units) below what was measured; measured number above the stated range.
By their numbers in this assay, from the lowest: compound 2; then compound 1; then compounds 4 and 3 (each within the scatter of the next).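

In this assay, the phenoxymethyl ring proves sensitive to a single added substituent and not only to replacement of the ring itself: methoxycarbonyl in place of hydrogen, on an aromatic carbon ortho to a large group, gives a 20-fold higher number from compound 2 to compound 4 (1.30 log units; beyond the scatter). Among the compounds shown here, the only earlier change at this ring was the swap to pyridin-3-yl, a 23-fold higher number from compound 2 to compound 3 (1.36 log units; beyond the scatter); both changes now raise the number by a large step, and compound 2 stays the lowest of the four at 1720 nM. Nothing measured in this set accounts for the rise, so it stands as an observation without an explanation.

The compounds shown do not separate the identity of the methoxycarbonyl group from its place on the ring, since one substituted example at one ring carbon cannot tell whether a methyl group or a fluorine atom at that place, or a carboxylic acid or primary amide in place of the ester, would stay near compound 2. Also open, as far as these compounds go, is whether methoxycarbonyl on another carbon of this ring would give a similar step.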